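Isopropyl Added to Two Related Acids in K562 Cells

The source may report more compounds than this note shows. Statements on the series, on what has been measured and on what is new or still open speak of the compounds shown alone.

Of the compounds shown here, three have been tested in a functional assay on K562 cells (Homo sapiens) for inhibition, read by MTT assay, with a stated time of 72 h; a higher number here means a weaker inhibitor, a lower number a stronger inhibitor. Compound 1 `CC(C)c1ccc(C(=O)/C=C/C(=O)O)c(C(C)C)c1` gives 4680 nM, and compound 2 `CC(C)c1cc(C(C)C)c(C(=O)/C=C/C(=O)O)c(C(C)C)c1` gives 4670 nM. These two differ in one place, (isopropyl in place of hydrogen on an aromatic carbon), and that change made a 1.0-fold lower number from compound 1 to compound 2 (0.00 log units; within the scatter). Compound 3 `CCc1ccc(C(C)C)cc1C(=O)/C=C/C(=O)O` gives 1360 nM, a number lower than both others by more than the usual scatter. How the core of compound 3 differs from the core of compound 1 is not broken down here.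

Compound 4 `CCc1c(C(=O)/C=C/C(=O)O)cc(C(C)C)cc1C(C)C` has not yet been measured in this assay. It differs from compound 3 by isopropyl in place of hydrogen on an aromatic carbon. Among the measured compounds shown here, this is the same kind of change as the one from compound 1 to compound 2, but the surroundings differ: here the entering group sits ortho to an ethyl group, meta to a (2-carboxyethenyl)carbonyl group and meta to an isopropyl group, whereas before it sat ortho to a (2-carboxyethenyl)carbonyl group and meta to two isopropyl groups. Because the earlier step of a 1.0-fold lower number from compound 1 to compound 2 (0.00 log units; within the scatter) stayed within the scatter, the expected step here is a 1.1-fold higher number from compound 3 to compound 4 (0.04 log units; within the scatter). Compound 4 is therefore estimated at about 1500 nM, most likely between 600 nM and 4000 nM.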

Compound 4, half-maximal inhibitory concentration: 5100 nM
Beside the measured number, compound 4's estimate is 3.4-fold (0.53 log units) below it; the whole stated range lies below it.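

In this assay, the added isopropyl group gave a 3.8-fold higher number from compound 3 to compound 4 (0.57 log units; beyond the scatter), so on this core the change left a weaker inhibitor. The same change therefore did not carry over unchanged from one core to the other: the same change on two cores in this assay, a 1.0-fold lower number (0.00 log units; within the scatter) from compound 1 to compound 2 and a 3.8-fold higher number (0.57 log units; beyond the scatter) from compound 3 to compound 4, 3.8-fold (0.57 log units) apart, beyond the scatter of two such steps

This shows that, in these two pairs, the effect of adding isopropyl depends on the core it is added to, but it does not show which difference between the cores is responsible, and the entering group's ortho ethyl group in compound 4 is only one candidate among the differences. With one pair on each core, it also says nothing about how the change would behave on any further core.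

From the compounds shown here alone, whether a methyl group or an amine in place of that isopropyl group on the core of compound 3 would also raise the number remains open. Also open, going by these compounds, is whether the same step would appear with a methyl ester in place of the carboxylic acid.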